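The source may hold more compounds than are shown below. What is called first, only, known or untested is meant among the compounds shown, and "the series" means these compounds.

Measured in a functional assay on HCT-116 cells (Homo sapiens) for antiproliferative activity, read by MTT assay, with a stated time of 72 h; on this read-out lower numbers stand for stronger inhibition and higher numbers for weaker inhibition:

- Compound 1 `CCCC(=O)NNC(=O)c1csc2ncc(-c3ccc(C)cc3)n12`: 34500 nM
- Compound 2 `CCC(=O)NNC(=O)c1csc2ncc(-c3ccc(OC)cc3)n12`: 64300 nM

Only these two compounds have been measured so far. Compound 2, at 64300 nM, lies within the usual scatter of compound 1, so the two cannot be told apart on these numbers. Both compounds share the same core but differ in more than one place, so neither value can be tied to a single structural change.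

The next compound to consider is compound 3 `CCCC(=O)NNC(=O)c1csc2ncc(-c3ccc(OC)cc3)n12`. It differs from compound 2 by one small edit: methyl in place of hydrogen on a saturated chain carbon, two bonds along the chain from a carbonyl carbon. In words, this is methyl in place of hydrogen on a saturated chain carbon, two bonds along the chain from a carbonyl carbon, and the chain changes from ethyl to propyl.

Among the measured compounds shown here, no measured pair shows this change on its own, so the data offer no direct guide. For such a small edit, no step beyond the scatter is expected in this assay, and no firm direction can be predicted. The estimate corresponds to an expected 1.3-fold lower number from compound 2 to compound 3 (0.11 log units; within the scatter). For compound 3 the estimated value is 50000 nM, with an expected range of 20000 nM to 120000 nM.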

Compound 3, half-maximal inhibitory concentration: 59100 nM
Estimate against measurement, compound 3: 1.2-fold (0.07 log units) below; measured number inside the range.
By their numbers in this assay, from the lowest: compounds 1, 3 and 2 (each within the scatter of the next).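

In this assay, methyl in place of hydrogen on a saturated chain carbon, two bonds along the chain from a carbonyl carbon, can now be read on its own, and it gives a 1.1-fold lower number from compound 2 to compound 3 (0.04 log units; within the scatter). Compound 3 also differs from compound 1 in a single place, so methoxy in place of methyl on an aromatic carbon can be read alone as well, giving a 1.7-fold higher number from compound 1 to compound 3 (0.23 log units; within the scatter). Neither single edit produces a step beyond the scatter, something that compound 1 and compound 2 could not show while they differed in more than one place, and no supporting data are available to explain this result.

The compounds shown cover only ethyl and propyl on the chain, so it remains open whether a longer chain such as hexyl, or a chain ending in an amine or a carboxylic acid, would give a step beyond the scatter. On the aromatic carbon only methyl and methoxy appear, which leaves open what a group such as chlorine, trifluoromethyl or nitrile would do there.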